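Swapping the Aryl Group on the Saturated Ring Carbon

A few compounds are considered here, and "the series" means these few. Any claim that something is new, unique, unknown or untested is made for them only; others in the source may bear on it.

The measured compounds so far:
Compound 1, `Cc1cc(O)c(C2=NN(c3ccc(S(N)(=O)=O)cc3)C(c3ccccc3Cl)C2)cc1Cl`, gives 79600 nM in a functional assay on UACC-257 cells (Homo sapiens) for antiproliferative activity, with a stated time of 48 h; a higher number here means a weaker inhibitor of growth, a lower number a stronger inhibitor of growth.
Compound 2, `Cc1cc(O)c(C2=NN(c3ccc(S(N)(=O)=O)cc3)C(/C=C/c3ccccc3)C2)cc1Cl`, gives 45700 nM in this assay.

On these two numbers compound 2 holds the lower one, but the gap to compound 1 is small: a 1.7-fold lower number from compound 1 to compound 2 (0.24 log units; within the scatter), so the two compounds cannot be separated with confidence in this assay.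

Compound 3, `COc1ccc(C2CC(c3cc(Cl)c(C)cc3O)=NN2c2ccc(S(N)(=O)=O)cc2)c(OC)c1OC`, has not yet been measured. It differs from compound 2 in one place: 2,3,4-trimethoxyphenyl in place of 2-phenylethenyl on a saturated ring carbon. The shared core, the 4-sulfamoylphenyl group and the 5-chloro-2-hydroxy-4-methylphenyl group stay the same.

For the measured compounds named here, only one measured step bears on this change, the exchange of one aryl group for another on the same saturated ring carbon from compound 1 to compound 2, and that step stayed within the scatter. Another exchange at that position is therefore expected to move the number little, if at all, in this assay. The step from compound 2 to compound 3 is estimated as a 1.1-fold higher number from compound 2 to compound 3 (0.04 log units; within the scatter). Compound 3 is expected to give about 50000 nM, most likely between 20000 nM and 150000 nM.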

Compound 3, concentration for total growth inhibition: 15200 nM
For compound 3 the middle estimate is 3.3-fold (0.52 log units) above the measured one, and the stated range ends above it.
By their numbers in this assay, from the lowest: compound 3; then compounds 2 and 1 (each within the scatter of the next).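

The exchange from compound 1 to compound 2 stayed within the scatter, which could have meant that the group on this saturated ring carbon matters little. The 2,3,4-trimethoxyphenyl group shows otherwise in this assay, with a 3.0-fold lower number from compound 2 to compound 3 (0.48 log units; beyond the scatter) and a 5.2-fold lower number from compound 1 to compound 3 (0.72 log units; beyond the scatter), so this position can shift the number beyond the scatter, and compound 3 holds the lowest number of the three. No measurement here explains these steps.

The entering group brings three methoxy groups at once, so these compounds cannot tell whether all three are needed or whether a single methoxy group on the phenyl ring would give a similar step. Also open, on these data alone, is how an amine or a carboxylic acid on that phenyl ring would change the number, and whether the step would hold if the 4-sulfamoylphenyl group or the 5-chloro-2-hydroxy-4-methylphenyl group were replaced.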